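The compounds below may be only part of what the source reports. "The series", "measured", "known", "first", "only" and "open" are said of these compounds alone.

Of the compounds shown here, three in this set have already been tested. Compound 1, with the structure `O=C1/C(=C/c2ccncc2)CNC/C1=C\c1ccccc1F`, and compound 2, with the structure `O=C1/C(=C/c2ccncc2)CN(S(=O)(=O)c2ccccc2)C/C1=C\c1ccccc1F`, share one core; compound 3, with the structure `O=C1/C(=C/c2cccnc2)CNC/C1=C\c1ccccc1C(F)(F)F`, carries a different core, and the difference between the two cores is not broken down here. Compound 4, with the structure `O=C1/C(=C/c2cccnc2)CN(S(=O)(=O)c2ccccc2)C/C1=C\c1ccccc1C(F)(F)F`, has not yet been tested.

In a functional assay on QGY-7703 cells (Homo sapiens) for cytotoxicity, read by MTT assay, with a stated time of 24 h (on this read-out lower numbers stand for stronger inhibition and higher numbers for weaker inhibition), compound 1 gives 14200 nM. In this assay compound 2 gives 8400 nM. The change between these two is phenylsulfonyl in place of hydrogen on an amine nitrogen in a ring, and it made the step of a 1.7-fold lower number from compound 1 to compound 2 (0.23 log units; within the scatter). In this assay compound 3 gives 3800 nM, the lowest number of the three, beyond the scatter from compound 2 and from compound 1.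

Compound 4 arises from compound 3 by phenylsulfonyl in place of hydrogen on an amine nitrogen in a ring, the same change as from compound 1 to compound 2, at the same place on each core. Within the data shown here, the one earlier example of this change gave a step that fell within the scatter, so on the evidence of compound 1 and compound 2 only a small move is expected here; the expected step is a 1.5-fold lower number from compound 3 to compound 4 (0.18 log units; within the scatter). Resting on the value of compound 3, which is 3800 nM, compound 4 is estimated to give 2500 nM in this assay, expected to lie between 1200 nM and 5500 nM.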

Compound 4, half-maximal inhibitory concentration: 6240 nM
Beside the measured number, compound 4's estimate is 2.5-fold (0.40 log units) below it; measured number outside the range, above it.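

In this assay, putting phenylsulfonyl in place of hydrogen on the amine nitrogen in the ring gave a 1.6-fold higher number from compound 3 to compound 4 (0.22 log units; within the scatter). Set beside the earlier example, this shows that the change does not carry over from one core to the other as a fixed shift, and that a step measured on one core was a poor guide to the step on the other: the same change on two cores in this assay, a 1.7-fold lower number (0.23 log units; within the scatter) from compound 1 to compound 2 and a 1.6-fold higher number (0.22 log units; within the scatter) from compound 3 to compound 4, 2.8-fold (0.44 log units) apart, beyond the scatter of two such steps. Among these compounds, it does not show that phenylsulfonyl clearly helps or harms on either core, as each step alone lies within the scatter, and with only two pairs of compounds it cannot be said which difference between the cores separates the two steps, or why.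

The compounds shown leave open how other groups on this nitrogen, such as methyl, acetyl or benzyl, would compare with hydrogen and phenylsulfonyl on each core. They also leave open which part of the core matters, something that pairs of compounds differing from one another in a single place on the core, each tested with and without phenylsulfonyl, could begin to settle.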